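The compounds below may be only part of what the source reports. "The series", "measured", "known", "first", "only" and "open" are said of these compounds alone.

Among the compounds with values here, in an assay on isolated protein for inhibition of ribosomal protein S6 kinase alpha-1 (Homo sapiens), read by mobility shift assay, tested at 30 uM (on this read-out lower numbers stand for less inhibition and higher numbers for more inhibition at the one concentration tested (going by the name of the read-out)), compound 2 `Cc1cc2c(c(N)nn2C)c(N2CC[C@H](O)C2)n1` gives -5%, the lowest of the two numbers measured so far. Its nearest neighbour is compound 1 `Cc1cc2c(c(N)nn2C)c(N2CCCCC2)n1`, which gives 23%. Within the data shown here, the one measured step, a number 28 percentage points lower from compound 1 to compound 2 (beyond the scatter), came from putting 3-hydroxypyrrolidin-1-yl in place of piperidin-1-yl on an aromatic carbon. Compound 3 `COCCNc1nc(C)cc2c1c(N)nn2C` has not yet been measured; it differs from compound 2 as follows: (2-methoxyethyl)amino in place of 3-hydroxypyrrolidin-1-yl on an aromatic carbon. Among the measured compounds shown here, no measured step shows what happens when a ring amine is replaced by an open chain such as (2-methoxyethyl)amino, so the only guide is that changing the group on this aromatic carbon shifted the read-out by a modest amount between compound 1 and compound 2. Since compound 2 already shows essentially no inhibition, the step of a number 10 percentage points higher from compound 2 to compound 3 (within the scatter) is expected to be small, in either direction. Compound 3 is therefore expected to give about 5% in this assay, within a range from -15% to 25%.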

Compound 3, a percentage reported as inhibition, at one concentration (the size of the read-out at that concentration, not a potency): -4%
Compound 3: middle estimate off by 9 percentage points, on the high side; measured number inside the range.
By their numbers in this assay, from the lowest: compounds 2 and 3 (each within the scatter of the next); then compound 1.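

In this assay, replacing the 3-hydroxypyrrolidin-1-yl ring with the open (2-methoxyethyl)amino chain gives a number 1 percentage points higher from compound 2 to compound 3 (within the scatter), so at this aromatic carbon, a ring is not needed for a number this low. Within the data shown here, replacing piperidin-1-yl with the same chain gives a number 27 percentage points lower from compound 1 to compound 3 (beyond the scatter), which leaves compound 1 as the only one of the three clearly above the others, and its piperidin-1-yl is the only one of these groups without an oxygen atom. Nothing available explains why these groups give different numbers.

On these data alone, what remains open is whether the higher number of compound 1 goes with its piperidine ring or with the lack of oxygen. A pentylamino chain, open and without oxygen, or a morpholin-4-yl ring, six-membered and with oxygen, could help separate the two.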